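Expecting a Trifluoromethyl Ortho Substituent to Weaken Inhibition

The compounds below may be only part of what the source reports. "The series", "measured", "known", "first", "only" and "open" are said of these compounds alone.

In a functional assay on A549 cells (Homo sapiens) for inhibition, read by MTT assay, with a stated time of 72 h (a higher number here means a weaker inhibitor, a lower number a stronger inhibitor), the three measured compounds gave:
compound 1 `COc1cc2c(Oc3ccc(NC(=O)c4nn(-c5ccccc5)c(=O)cc4C)cc3F)ccnc2cc1OCCCN1CCCCC1`, 150 nM;
compound 2 `COc1cc2c(Oc3ccc(NC(=O)c4nn(-c5ccccc5)c(=O)cc4C)cc3F)ccnc2cc1OCCCN1CCN(C)CC1`, 350 nM;
compound 3 `COc1cc2c(Oc3ccc(NC(=O)c4nn(-c5ccccc5C)c(=O)cc4C)cc3F)ccnc2cc1OCCCN1CCCCC1`, 1920 nM.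

Compound 2 stands second highest of the three numbers, with compound 1 nearest below it and compound 3 furthest above it. Compound 4 `COc1cc2c(Oc3ccc(NC(=O)c4nn(-c5ccccc5C(F)(F)F)c(=O)cc4C)cc3F)ccnc2cc1OCCCN1CCN(C)CC1` differs from compound 2 by trifluoromethyl in place of hydrogen on an aromatic carbon. Among the measured compounds shown here, no measured step makes exactly this change, but the step of a 13-fold higher number from compound 1 to compound 3 (1.11 log units; beyond the scatter), a methyl in place of hydrogen on an aromatic carbon at the same place, points the way, while the step of a 2.3-fold higher number from compound 1 to compound 2 (0.37 log units; beyond the scatter) shows the chain-end change to be only modest. A large rise in this assay is therefore expected, a 13-fold higher number from compound 2 to compound 4 (1.11 log units; beyond the scatter). Compound 4 is estimated at 4500 nM, between 1200 nM and 16000 nM.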

Compound 4, half-maximal inhibitory concentration: 170 nM
For compound 4 the middle estimate is 26-fold (1.42 log units) above the measured one, and the stated range ends above it.
By their numbers in this assay, from the lowest: compounds 1 and 4 (each within the scatter of the next); then compound 2; then compound 3.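

In this assay, trifluoromethyl on this aromatic carbon gives a 2.1-fold lower number from compound 2 to compound 4 (0.31 log units; beyond the scatter), so a group placed here need not weaken inhibition. The earlier change at this place, methyl, gave a 13-fold higher number from compound 1 to compound 3 (1.11 log units; beyond the scatter), but it started from the piperidin-1-yl chain end, so the contrast may come from the group, the chain end or both. No measurement shown explains the difference between these two steps.

Still open, as far as these compounds go, is how trifluoromethyl behaves with the piperidin-1-yl chain end, and methyl with the 4-methylpiperazin-1-yl chain end. A methoxy group or a chlorine atom on this carbon also remains an open case.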